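This account rests on a few compounds, and the source may have more. Where it says the series, first, only, none or still open, it means among the compounds named here.

In an ADME assay on BJ cells (Homo sapiens) for cytotoxicity, read by CellTiter-Glo and resazurin assay, with a stated time of 72 h (on this read-out higher numbers stand for an effect only at larger amounts of compound and lower numbers for an effect already at smaller amounts), compound 3 `CCOC(=O)CCCCCOc1cccc(CN(C(=O)c2ccc(-c3cccc(CC(=O)O)c3)cc2)C(C)C)c1` gives only a limit, > 26000 nM. Its two measured neighbours stand the same way. Compound 1 `CCOC(=O)CCCCCOc1cccc(CN(C(=O)c2ccc(-c3cccc(OCc4ccccc4)c3)cc2)C(C)C)c1` gives a limit, > 26000 nM. Compound 2 `CCOC(=O)CCCCCOc1cccc(CN(C(=O)c2ccc(-c3cc(F)cc(OC)c3)cc2)C(C)C)c1` gives a limit as well, > 26000 nM. Within the data shown here, the steps into compound 3, a step that the two limits leave unreadable from compound 1 to compound 3 and a step that the two limits leave unreadable from compound 2 to compound 3, therefore cannot be read because the limit of > 26000 nM in this assay, at which 3 of the 3 values shown sit, holds every value measured so far, and the exchange of a benzyloxy or of a 3-fluoro-5-methoxyphenyl for a carboxymethyl left nothing visible on this read-out.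

Compound 4 `CCOC(=O)CCCCCOc1cccc(CN(C(=O)c2ccc(-c3cccc([N+](=O)[O-])c3)cc2)C(C)C)c1` differs from compound 3 by nitro in place of carboxymethyl on an aromatic carbon. Among the measured compounds shown here, no measured step bears directly on such a change; what the neighbours show is only that three different groups on the same aromatic carbon all left the compounds at the limit. For compound 4 the expected step is a number no higher from compound 3 to compound 4 (the limit leaves the size open), that is, no movement beyond the scatter, with compound 4 most likely reported at the limit again. Compound 4 is therefore estimated at 26000 nM in this assay, with a range from 15000 nM to 50000 nM, the numbers being a placeholder for a value that will most probably again be given only as a limit.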

Compound 4, half-maximal effective concentration: < 1.3 nM
Compound 4 was reported as a limit (the forecaster's own chance of this, stated with the estimate: 85%); middle value at least 20000-fold (4.30 log units) from the limit.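

In this assay, this place on an aromatic carbon, meta to a large group, proves able to carry a very large change: nitro in place of carboxymethyl gives an at least 20000-fold lower number from compound 3 to compound 4 (4.30 log units; beyond the scatter), nitro in place of benzyloxy gives an at least 20000-fold lower number from compound 1 to compound 4 (4.30 log units; beyond the scatter), and 3-nitrophenyl in place of 3-fluoro-5-methoxyphenyl gives an at least 20000-fold lower number from compound 2 to compound 4 (4.30 log units; beyond the scatter). The three earlier compounds had shown only that different groups here left the read-out unmoved, and now a single exchange of one small group, with the rest of the molecule unchanged, separates the compounds at the two ends of the assay's range: the limit of > 26000 nM in this assay, at which 3 of the 4 values shown sit. Compound 4 itself stands at a limit, so each step has a known minimum but no known full size: the limit of < 1.3 nM in this assay, at which 1 of the 4 values shown sits.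

Whether the effect belongs to nitro alone stays open, since the compounds shown do not tell how an amine, a nitrile or a carboxylic acid set directly on this aromatic carbon would behave. Also open, on these data alone, is how far compound 4 lies past its limit, and whether nitro at this place keeps its effect when the rest of the shared core, such as the ester chain, is changed.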